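From Compound 3 to Compound 4 in a Cytotoxicity Test

The compounds below may be only part of what the source reports. "The series", "measured", "known", "first", "only" and "open" are said of these compounds alone.

Measured in a functional assay on SN12C cells (Homo sapiens) for cytotoxicity, read by sulforhodamine B assay, with a stated time of 48 h, tested at 0.01 uM; on this read-out lower numbers stand for a stronger effect and higher numbers for a weaker effect at the one concentration tested:
Compound 1 `COc1cc(-c2cc(/C=C/C(=O)c3ccc(N)cc3)[nH]n2)cc(OC)c1OC` — compound 1 gives 98%
Compound 2 `COc1ccc(-c2cc(/C=C/C(=O)c3cc(OC)c(OC)c(OC)c3)[nH]n2)cc1OC` — compound 2 gives 98%
Compound 3 `COc1ccc(C(=O)/C=C/c2cc(-c3cc(OC)c(OC)c(OC)c3)n[nH]2)cc1` — compound 3 gives 99%

On the numbers shown, compound 3 stands at the top of the three, but the three values sit within the scatter of one another: the step of a number 1 percentage points higher from compound 1 to compound 3 (within the scatter) is small, and compound 2 lies equally close. In other words, none of the three shows a marked effect at the concentration tested.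

Compound 4 `COc1cc(-c2cc(/C=C/C(=O)c3ccc(F)c(F)c3)[nH]n2)cc(OC)c1OC` differs from compound 3 as follows: 3,4-difluorophenyl in place of 4-methoxyphenyl on a carbonyl carbon. Within the data shown here, the only measured step that bears on a change of the aryl group on this carbonyl carbon is the one from compound 1 to compound 3, which stayed within the scatter. Among the measured compounds shown here, no compound carrying fluorine has been measured, so the expectation rests on the flat picture given by compounds 1, 2 and 3.

Compound 4 is therefore expected to give about 97%, with a range from 88% to 105%. The step of a number 2 percentage points lower from compound 3 to compound 4 (within the scatter) is expected to fall within the scatter, in no clear direction.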

Compound 4, a percentage reported as activity, at one concentration (the size of the read-out at that concentration, not a potency): 95%
The estimate for compound 4 lay 2 percentage points above the measured number; the measured number falls inside the stated range.
By their numbers in this assay, from the lowest: compounds 4, 1, 2 and 3 (each within the scatter of the next).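

Putting 3,4-difluorophenyl in place of 4-methoxyphenyl on the carbonyl carbon gives a number 4 percentage points lower from compound 3 to compound 4 (within the scatter) in this assay, and putting it in place of 4-aminophenyl gives a number 3 percentage points lower from compound 1 to compound 4 (within the scatter) as the second step at this place. The earlier compounds shown here covered only the methoxy and amino versions of this aryl group, so fluorine is a new kind of substituent here, and it too leaves the read-out within the scatter at the one concentration tested. No evidence is available that would explain these small steps.

From the compounds shown here alone, whether a carboxylic acid, a nitrile or a longer chain in place of this aryl group would move the number beyond the scatter remains open. Going by these compounds, it also remains open whether these compounds would stay as closely grouped at any other concentration.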